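One Double Bond Redrawn, Same Atoms

This account rests on a few compounds, and the source may have more. Where it says the series, first, only, none or still open, it means among the compounds named here.

Of the compounds shown here, two have been measured so far in a functional assay on DU-145 cells (Homo sapiens) for cytotoxicity, read by MTT assay, with a stated time of 48 h; a higher number here means a weaker inhibitor, a lower number a stronger inhibitor. Compound 1 `C=C/C(C)=C/CC/C(C)=C/c1cc(C(=O)O)co1` gives 38900 nM, and compound 2 `C=C/C(C)=C\CC/C(C)=C/c1cc(C(=O)OC)co1` gives 59300 nM. These two numbers lie within the usual scatter of repeated measurements, so they cannot be ranked against each other.

Compound 3 `C=C/C(C)=C/CC/C(C)=C/c1cc(C(=O)OC)co1` has not yet been measured. Set against compound 2, it shows this difference: the two compounds have the same atoms and bonds and differ only in configuration as drawn: 1 of 2 stereo elements differ; a double bond is drawn Z in compound 2 and E in compound 3. Nothing leaves and nothing enters: a double bond is drawn Z in compound 2 and E in compound 3.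

Among the measured compounds shown here, no measured pair shows what a change of this kind does on its own, so the data give no direction for it. For the measured compounds named here, the only guide is how close the measured compounds already are, with compound 1 at 38900 nM and compound 2 at 59300 nM. No step beyond the scatter is therefore expected in this assay. The expected change is small, a 1.2-fold lower number from compound 2 to compound 3 (0.07 log units; within the scatter), and this estimate stays within the scatter. Compound 3 is expected at 50000 nM, with an estimated range from 24000 nM to 100000 nM.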

Compound 3, half-maximal inhibitory concentration: 25100 nM
For compound 3 the middle estimate is 2.0-fold (0.30 log units) above the measured one, within the range that was stated.
By their numbers in this assay, from the lowest: compounds 3, 1 and 2 (each within the scatter of the next, the first and the last beyond it).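

In this assay, redrawing one double bond from Z to E gives a 2.4-fold lower number from compound 2 to compound 3 (0.37 log units; beyond the scatter), a modest step, but the only one in this small set that lies beyond the scatter. The step can be tied to the drawn geometry of that double bond alone, because no atom or bond separates the pair: the fact that compounds 2 and 3 differ only in the configuration as drawn. Placing methyl in place of hydrogen on an oxygen next to a carbonyl group gives a 1.5-fold lower number from compound 1 to compound 3 (0.19 log units; within the scatter), so with this double bond drawn E, that swap cannot be told apart from repeat-measurement noise.

The compounds shown leave open whether the same redrawing would give a step of like size and direction in a compound with hydrogen rather than methyl on that oxygen, since only one Z compound appears here. They also leave open how the number would respond if an ethyl group or an amide stood in that place, or if the chain carrying the double bond were longer.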